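The source may hold more compounds than are shown below. What is called first, only, known or untested is meant among the compounds shown, and "the series" means these compounds.

Within the data shown here, in a functional assay on MX1 cells (Homo sapiens) for inhibition, read by MTT assay, with a stated time of 120 h (on this read-out lower numbers stand for stronger inhibition and higher numbers for weaker inhibition), compound 1 `O=C(CCc1ccc(NC(=O)Nc2ccc(Cl)c(C(F)(F)F)c2)cc1)NC1CCC1` gives 24000 nM, the only true number so far, and it marks weak inhibition. Compound 2 `C/C(=C\C(=O)N1CC(C)OC(C)C1)c1ccc(NC(=O)Nc2ccc(Cl)c(C(F)(F)F)c2)cc1` gives no number, only a limit of the assay: > 50000 nM. On these data alone, the place of compound 2 therefore remains open at the weak end of this assay, with no exact rank against compound 1.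

Compound 3 `CNC(=O)/C=C(\C)c1ccc(NC(=O)Nc2ccc(Cl)c(C(F)(F)F)c2)cc1` carries methylamino in place of 2,6-dimethylmorpholin-4-yl on a carbonyl carbon. Among the measured compounds shown here, no measured pair isolates this change, so its size cannot be read from the data. With compound 1 at 24000 nM, weak inhibition is expected again. The expected change is small, towards stronger inhibition: an at least 1.6-fold lower number from compound 2 to compound 3 (0.22 log units; that floor lies within the scatter). For compound 3 the estimated value is 30000 nM, with an expected range of 10000 nM to 50000 nM.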

Compound 3, half-maximal inhibitory concentration: > 50000 nM
Compound 3: no number, only a limit; the forecaster's own chance of this, stated with the estimate: 40%; middle value at least 1.6-fold (0.22 log units) away from the limit.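

In this assay compound 3 gives only a limit, as compound 2 does, so the step between them cannot be read and the exchange of 2,6-dimethylmorpholin-4-yl for methylamino on the carbonyl carbon has no measurable size. Among these compounds, the one readable comparison is with compound 1: 1-methyl-2-(methylcarbamoyl)ethenyl in place of 2-(cyclobutylcarbamoyl)ethyl on an aromatic carbon gives an at least 2.0-fold higher number from compound 1 to compound 3 (0.31 log units; beyond the scatter). Neither group on the carbonyl carbon brings a true number, and the weak end of the series now rests on one assay limit: the limit of > 50000 nM in this assay, at which 2 of the 3 values shown sit.

On these data alone, how far compound 2 and compound 3 lie past that limit stays open, as does any order between them. Also open, as far as these compounds go, is whether an unsubstituted amino group, a carboxylic acid or a longer chain on the carbonyl carbon would give a true number.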